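A few compounds are considered here, and "the series" means these few. Any claim that something is new, unique, unknown or untested is made for them only; others in the source may bear on it.

Compound 1 `Cc1ccc(-c2cn(-c3ccc(CN4CCN(C)CC4)cc3)nn2)cc1Nc1nccc(-c2cccnc2)n1` and compound 2 `Cc1ccc(-c2cn(-c3ccc(CN4CCN(C)CC4)c(C(F)(F)F)c3)nn2)cc1Nc1nccc(-c2cccnc2)n1` share one core and differ in one place. Among the compounds with values here, in a functional assay on HL-60 cells (Homo sapiens) for inhibition, read by MTT assay, with a stated time of 72 h (a lower number here means a stronger inhibitor, a higher number a weaker inhibitor), compound 1 gives 6740 nM, the higher of the two numbers measured so far; compound 2 gives 20 nM. Within the data shown here, the only measured step, a 340-fold lower number from compound 1 to compound 2 (2.53 log units; beyond the scatter), concerns a trifluoromethyl in place of hydrogen on an aromatic carbon. Compound 3 `Cc1ccc(-c2cn(-c3ccc(CN4CCCCC4)cc3)nn2)cc1Nc1nccc(-c2cccnc2)n1` is not yet measured. It differs from compound 1 elsewhere: piperidin-1-yl in place of 4-methylpiperazin-1-yl on a saturated chain carbon bound to an aromatic carbon. Among the measured compounds shown here, no measured step touches this change; the step from compound 1 to compound 2 speaks only of the trifluoromethyl and gives no guide to a change at the saturated chain carbon. The change to compound 3 is therefore expected to bring no step beyond the scatter in this assay, an expected 1.0-fold lower number from compound 1 to compound 3 (0.00 log units; within the scatter). Compound 3 is estimated at 6700 nM in this assay, with a range from 2000 nM to 22000 nM.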

Compound 3, half-maximal inhibitory concentration: 740 nM
Beside the measured number, compound 3's estimate is 9.1-fold (0.96 log units) above it, outside the stated range (below it).
By their numbers in this assay, from the lowest: compound 2; then compound 3; then compound 1.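

The group on a saturated chain carbon bound to an aromatic carbon is not a silent place in this assay: replacing 4-methylpiperazin-1-yl with piperidin-1-yl gives a 9.1-fold lower number from compound 1 to compound 3 (0.96 log units; beyond the scatter). Thus the trifluoromethyl on the aromatic carbon is not the only change that moves the number, although its step, a 340-fold lower number from compound 1 to compound 2 (2.53 log units; beyond the scatter), remains the larger of the two. The ring that enters has 1 hetero atom where the ring that leaves has 2, but no measurement here accounts for the shift.

The compounds shown leave open how morpholin-4-yl or pyrrolidin-1-yl would read at this place. They also leave open whether the piperidin-1-yl and trifluoromethyl steps would add up in a single compound carrying both groups.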